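The source may hold more compounds than are shown below. What is called first, only, known or untested is meant among the compounds shown, and "the series" means these compounds.

Measured so far in a functional assay on HT-29 cells (Homo sapiens) for cytotoxicity, read by MTT assay, with a stated time of 24 h; on this read-out lower numbers stand for stronger inhibition and higher numbers for weaker inhibition:
Compound 1 `Cc1ccc2oc(SCC(=O)Nc3ccc(-c4nc(-c5ccccc5)c(-c5ccccc5)n4C)cc3)nc2c1` gives 22.4 ug/mL.
Compound 2 `Cn1c(-c2ccc(NC(=O)CSc3nc4ccccc4s3)cc2)nc(-c2ccccc2)c1-c1ccccc1` gives 18 ug/mL.
Compound 3 `Cn1c(-c2ccc(NC(=O)CSC3=NCCS3)cc2)nc(-c2ccccc2)c1-c1ccccc1` gives 21 ug/mL.

Compound 3 stands second highest of the three numbers. Its nearest neighbour is compound 1, with a 1.1-fold lower number from compound 1 to compound 3 (0.03 log units; within the scatter), and its furthest is compound 2, with a 1.2-fold higher number from compound 2 to compound 3 (0.07 log units; within the scatter). Both gaps, and also a 1.2-fold lower number from compound 1 to compound 2 (0.09 log units; within the scatter), lie within the usual scatter of repeated measurements, so the three compounds cannot be told apart on these numbers.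

Compound 4 `CCN1CCN(CC(=O)Nc2ccc(-c3nc(-c4ccccc4)c(-c4ccccc4)n3C)cc2)CC1` has not yet been measured. Compared with compound 3 it carries a group of 8 heavy atoms (6 carbon, 2 nitrogen; one six-membered non-aromatic ring with 2 hetero atoms) in place of a group of 6 heavy atoms (3 carbon, 1 nitrogen, 2 sulfur; one five-membered non-aromatic ring with 2 hetero atoms), on a saturated chain carbon bound to a carbonyl carbon. For the measured compounds named here, every measured step so far swapped only the group sitting on the sulfur and kept the rest of the chain; here the whole sulfur-containing group leaves and a 4-ethylpiperazin-1-yl enters, so no measured step covers this change directly. Going by the values given here, the three steps that do exist all stayed within the scatter, which is the only guide available, but a change of this kind is larger than any of them. The step from compound 3 to compound 4 is therefore expected to be none beyond the scatter, written as a 1.0-fold higher number from compound 3 to compound 4 (0.02 log units; within the scatter), with a wide range to allow for the unknown. Compound 4 is estimated at 22 ug/mL, with a range from 8 ug/mL to 60 ug/mL.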

Compound 4, half-maximal inhibitory concentration: 75 ug/mL
The estimate for compound 4 lay 3.4-fold (0.53 log units) below the measured number; the measured number lies above the stated range.
By their numbers in this assay, from the lowest: compounds 2, 3 and 1 (each within the scatter of the next); then compound 4.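

In this assay, for the compounds shown here, putting 4-ethylpiperazin-1-yl on the saturated chain carbon bound to a carbonyl carbon gives the first steps in this set that lie beyond the scatter: there is a 3.6-fold higher number from compound 3 to compound 4 (0.55 log units; beyond the scatter) and a 4.2-fold higher number from compound 2 to compound 4 (0.62 log units; beyond the scatter) and also a 3.3-fold higher number from compound 1 to compound 4 (0.52 log units; beyond the scatter) on the same read-out. The three sulfur-linked groups differ in ring type and size yet cannot be told apart, so this position did not look sensitive until the sulfur-linked group was replaced, and compound 4 is now the weakest of the four, though each step is only modest. Nothing measured here explains why the number rises.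

Compound 4 changes the linking sulfur and the ring in a single step, so these compounds cannot show which of the two matters, and a 4-ethylpiperazin-1-yl group held on a sulfur in the chain would separate them. Going by these compounds, it also stays open whether the effect belongs to this particular ring or to amines at this place more widely, which a morpholin-4-yl group, a 4-methylpiperazin-1-yl group or an open-chain diethylamino group could test.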